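This account rests on a few compounds, and the source may have more. Where it says the series, first, only, none or still open, it means among the compounds named here.

Measured so far:
compound 1 `Cc1ccc2oc(SCC(=O)Nc3ccc(-c4nc(-c5ccccc5)c(-c5ccccc5)n4C)cc3)nc2c1`: 1.1%
compound 2 `Cn1cnnc1SCC(=O)Nc1ccc(-c2nc(-c3ccccc3)c(-c3ccccc3)n2C)cc1`: 33.1%

In a functional assay on MCF7 cells (Homo sapiens) for cytotoxicity, read by MTT assay, with a stated time of 24 h, tested at 0.64 ug/mL (a higher number here means a stronger effect of the compound at the concentration tested, a lower number a weaker effect), compound 2 gives 33.1%, the highest of the two numbers; compound 1 gives 1.1%. Going by the values given here, the only recorded step is a number 32 percentage points higher from compound 1 to compound 2 (beyond the scatter), an exchange of the group on the same sulfur. Compound 3 `Cn1c(-c2ccc(NC(=O)CSC3=NCCS3)cc2)nc(-c2ccccc2)c1-c1ccccc1` differs from compound 2 by a group of 5 heavy atoms (3 carbon, 1 nitrogen, 1 sulfur; one five-membered non-aromatic ring with 2 hetero atoms) in place of a group of 6 heavy atoms (3 carbon, 3 nitrogen; one five-membered aromatic ring with 3 hetero atoms), on a sulfur. That one step shows the group on the sulfur can move the read-out strongly, but gives no direction for a non-aromatic ring; a moderate fall is expected, a number 13.1 percentage points lower from compound 2 to compound 3 (beyond the scatter). Compound 3 is estimated at 20%, with a range from 3% to 45%.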

Compound 3, a percentage reported as activity, at one concentration (the size of the read-out at that concentration, not a potency): 10.3%
Beside the measured number, compound 3's estimate is 9.7 percentage points above it; measured number inside the range.
By their numbers in this assay, from the lowest: compounds 1 and 3 (each within the scatter of the next); then compound 2.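

On the sulfur, a five-membered non-aromatic ring in place of 4-methyl-4H-1,2,4-triazol-3-yl gives a number 22.8 percentage points lower from compound 2 to compound 3 (beyond the scatter) in this assay, so the read-out of the triazole group does not carry over to this ring. The same ring in place of 5-methyl-1,3-benzoxazol-2-yl gives a number 9.2 percentage points higher from compound 1 to compound 3 (within the scatter), so among the three groups only 4-methyl-4H-1,2,4-triazol-3-yl stands apart. No evidence on why these groups differ is at hand.

Open, on these data alone, is how an amine or a carboxylic acid on this sulfur would read, and whether a triazole without its methyl group would keep the read-out.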